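The compounds below may be only part of what the source reports. "The series", "measured", "known", "first", "only" and "open" are said of these compounds alone.

Compound 1 `Clc1ccc(-c2cc(-c3cccnc3)nc(-c3cccs3)c2)o1` gives 1240 nM in a functional assay on HCT-15 cells (Homo sapiens) for cytotoxicity, in the presence of a further agent that is not named here (on this read-out higher numbers stand for weaker inhibition and lower numbers for stronger inhibition), and compound 2 `Cc1ccccc1-c1cc(-c2ccc(Cl)o2)cc(-c2ccsc2)n1` gives 4630 nM in this assay, so compound 1 stands lowest of the two numbers shown. Compound 3 `Clc1ccc(-c2cc(-c3ccsc3)nc(-c3ccccn3)c2)o1` reaches only a limit of this assay, > 50000 nM, as recorded in the limit of > 50000 nM in this assay, at which 1 of the 3 values shown sits. Among the measured compounds shown here, the single measured step, an at least 10-fold higher number from compound 2 to compound 3 (1.03 log units; beyond the scatter), is large. Compound 4 `Clc1ccc(-c2cc(-c3ccc(Cl)o3)cc(-c3cccs3)n2)cc1` carries 4-chlorophenyl in place of pyridin-3-yl on an aromatic carbon. That measured step runs the other way, from a carbon-only ring to a pyridyl, and concerns a different attachment, so it bears on the present change only loosely; exchanging the pyridyl for a carbon-only ring is expected to lower the number by a modest step, a 1.6-fold lower number from compound 1 to compound 4 (0.19 log units; within the scatter), if at all. The estimate for compound 4 in this assay is 800 nM, within 250 nM to 3000 nM.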

Compound 4, half-maximal inhibitory concentration: 14200 nM
Beside the measured number, compound 4's estimate is 18-fold (1.25 log units) below it, and the stated range ends below it.
By their numbers in this assay, from the lowest: compound 1; then compound 2; then compound 4. At a limit, above all of these: compound 3.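

In this assay, at this position next to the ring nitrogen, the carbon-only ring carries the higher number (an 11-fold higher number from compound 1 to compound 4 (1.06 log units; beyond the scatter)). The earlier step (an at least 10-fold higher number from compound 2 to compound 3 (1.03 log units; beyond the scatter)) had the pyridyl on the higher side, so across these two pairs no single direction holds for pyridyl against carbon-only rings. Nothing shown accounts for the new step.

Going by these compounds, whether that step follows the loss of the ring nitrogen or the entry of chlorine stays open. Also open, on these data alone, is how an unsubstituted phenyl, or a pyridin-3-yl carrying an amine or a carboxylic acid, would read here.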